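Replacing Trichloromethyl on a Short-Lived Compound

A few compounds are considered here, and "the series" means these few. Any claim that something is new, unique, unknown or untested is made for them only; others in the source may bear on it.

Among the compounds with values here, in an in vitro ADME assay on microsomes from liver (Simiiformes) (on this read-out higher numbers stand for a longer-lived compound and lower numbers for a shorter-lived compound), compound 2 `Cc1cc(CCCOc2c(C)cc(-c3noc(C(Cl)(Cl)Cl)n3)cc2C)on1` gives 0.183 h, the only exact number so far. Compound 1 `Cc1cc(-c2noc(C3CC3)n2)cc(C)c1OCCCc1cc(CO)no1` gives > 2.5 h, which is a limit and not a number. Compound 3 `Cc1cc(CCCOc2c(C)cc(-c3noc(C(C)(F)F)n3)cc2C)on1` has the same core as compound 2 but carries 1,1-difluoroethyl in place of trichloromethyl on an aromatic carbon. Within the data shown here, no measured pair shows this change, so the expectation rests on the structures alone: a longer half-life, with a rise well beyond the scatter. The estimated change is a 6.6-fold higher number from compound 2 to compound 3 (0.82 log units; beyond the scatter). For compound 3 the expected value is 1.2 h, within an estimated range of 0.4 h to 3.5 h.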

Compound 3, half-life: 1.1 h
For compound 3 the middle estimate is 1.1-fold (0.04 log units) above the measured one; the range from low to high includes it.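

At this place on the ring, next to the ring nitrogen and the ring oxygen, 1,1-difluoroethyl in place of trichloromethyl gives a 6.0-fold higher number from compound 2 to compound 3 (0.78 log units; beyond the scatter) in this assay. Within the data shown here, this is the only measured step so far, and it shows that exchanging these two groups, which have the same heavy-atom count, can alone move the half-life beyond the scatter. Compound 1 differs in more than one place and carries a limit, not a number: the limit of > 2.5 h in this assay, at which 1 of the 3 values shown sits.

Going by these compounds, how trifluoromethyl or an amine would fare at this place stays open. So does whether the loss of chlorine or the gain of fluorine accounts for the rise.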